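Chloro series on Hs-578T cells: notes before compound 4

The compounds below may be only part of what the source reports. "The series", "measured", "known", "first", "only" and "open" are said of these compounds alone.

The set comprises three measured compounds and one awaiting measurement. Compound 1 `ClCc1cccc(Cn2cnc3ncnc(Cl)c32)c1` and compound 2 `ClCc1cccc(Cn2cnc3c(Cl)ncnc32)c1` are built from the same atoms joined differently; the difference between the two cores is not broken down here. In a functional assay on Hs-578T cells (Homo sapiens) for cytotoxicity, read by sulforhodamine B assay, with a stated time of 48 h (a lower number here means a stronger inhibitor of growth, a higher number a weaker inhibitor of growth), compound 1 gives 18200 nM, the highest number of the three, and compound 2 gives 3460 nM. Compound 3 `ClCc1cccc(Cn2cnc3c(Cl)nc(Cl)nc32)c1` carries one further chlorine on the core of compound 2, and in this assay compound 3 gives 1990 nM.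

The change from compound 2 to compound 3 is chloro in place of hydrogen on an aromatic carbon. Its step, a 1.7-fold lower number from compound 2 to compound 3 (0.24 log units; within the scatter), is a small one. Compound 4 `ClCc1cccc(Cn2cnc3nc(Cl)nc(Cl)c32)c1` applies the same change to compound 1: chloro in place of hydrogen on an aromatic carbon. The surroundings of the new chlorine are described in the same words for both pairs, so the change is the same, only the core beneath it differs.

Among the compounds with values here, the expectation for compound 4 rests on the single measured example of this change, the step of a 1.7-fold lower number from compound 2 to compound 3 (0.24 log units; within the scatter), applied to the value of compound 1, 18200 nM. Because compound 2 to compound 3 showed a 1.7-fold lower number from compound 2 to compound 3 (0.24 log units; within the scatter), the estimated step for compound 4 is a 1.7-fold lower number from compound 1 to compound 4 (0.22 log units; within the scatter). Within the data shown here, with only one prior example, the range is kept wide. Compound 4 is thus expected to give about 11000 nM in this assay, estimated to lie between 4000 nM and 25000 nM.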

Compound 4, concentration for 50% growth inhibition: 1410 nM
For compound 4 the middle estimate is 7.8-fold (0.89 log units) above the measured one; the measured number lies below the stated range.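

In this assay, within the data shown here, the change of chloro in place of hydrogen on an aromatic carbon, here between two ring nitrogen atoms, gives a 13-fold lower number from compound 1 to compound 4 (1.11 log units; beyond the scatter), and this step does not match the one for the same change on the other core: the same change on two cores in this assay, a 1.7-fold lower number (0.24 log units; within the scatter) from compound 2 to compound 3 and a 13-fold lower number (1.11 log units; beyond the scatter) from compound 1 to compound 4, 7.4-fold (0.87 log units) apart, beyond the scatter of two such steps. The size of the step therefore does not carry from one core to the other in this series, and a value for one core cannot simply be read across from the step measured on the other. Among these compounds, the two pairs do not show why the steps part, nor which of them is nearer the usual behaviour of this change, and as the only two examples, both from a single cell line and read-out, they support no general rule about the cores.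

What the compounds shown leave open is whether a different group on that aromatic carbon, such as an amine, a methoxy group or a fluoro group, would also give steps that depend on the core. Also open, going by these compounds, is whether the same gap between the cores would hold if the chloromethyl group on the benzene ring gave way to a hydroxymethyl group or a longer chain.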